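Chalcone Piperazines in Mice: Aryl to Sulfonyl

The compounds below may be only part of what the source reports. "The series", "measured", "known", "first", "only" and "open" are said of these compounds alone.

Measured compounds:
compound 1 `O=C(/C=C/c1ccccc1)c1ccc(N2CCN(c3cccc(Cl)c3)CC2)cc1`, 14.1%
compound 2 `COc1ccccc1N1CCN(c2ccc(C(=O)/C=C/c3ccc(Cl)cc3)cc2)CC1`, 6.13%

In a functional assay on the whole organism (strain Kunming) for inhibition, with Mus musculus as the target, with a stated time of 1 h, at a dose of 40 mg/kg by the oral route (a higher number here means more inhibition at the dose given (going by the name of the read-out), a lower number less inhibition), compound 1 gives 14.1%; compound 2 gives 6.13%, a gap that lies within the usual scatter, so the two cannot be told apart. Compound 3 `O=C(/C=C/c1ccccc1)c1ccc(N2CCN(S(=O)(=O)c3ccccc3)CC2)cc1` differs from compound 1 in one place: phenylsulfonyl in place of 3-chlorophenyl on an amine nitrogen in a ring. Going by the values given here, no step between measured compounds bears on this change, and the expected step is a number 2.1 percentage points lower from compound 1 to compound 3 (within the scatter), nothing beyond the scatter in either direction. Compound 3 is accordingly estimated to give 12%, within a range from 0% to 30%.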

Compound 3, a percentage reported as inhibition, in the whole organism at one dose (the size of the read-out at that dose, not a potency): 30%
For compound 3 the middle estimate is 18 percentage points below the measured one, within the range that was stated.
By their numbers in this assay, from the lowest: compounds 2 and 1 (each within the scatter of the next); then compound 3.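

Replacing 3-chlorophenyl with phenylsulfonyl on this amine nitrogen in a ring gives a number 15.9 percentage points higher from compound 1 to compound 3 (beyond the scatter) in this assay. Going by these compounds alone, this is the first step in the set beyond the usual scatter, and it shows that the read-out depends on the group at this position. No measurement at hand accounts for the step.

The change both adds the sulfonyl link and removes the chlorine, and the compounds shown do not separate the two. Nor do they show how a methylsulfonyl group or a 3-chlorophenylsulfonyl group would behave at this nitrogen.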